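The compounds below may be only part of what the source reports. "The series", "measured", "known", "first", "only" and "open" are said of these compounds alone.

Measured compounds in an assay on 32D cells for inhibition of interleukin-15 (Mus musculus), read by resazurin assay, with stated times of 30 min and 2.5 days, in the presence of a further agent that is not named here; on this read-out lower numbers stand for stronger inhibition and higher numbers for weaker inhibition:
compound 1 `Cn1c(Cc2nn(C)c(=O)c3ccccc23)nnc1SCC(=O)Nc1ccc(Cl)cc1Cl` gives 21100 nM;
compound 2 `Cn1nc(Cc2nnc(SCC(=O)Nc3ccc(Cl)cc3Cl)n2CCC=O)c2ccccc2c1=O` gives 6400 nM;
compound 3 `Cn1nc(Cc2nnc(SCC(=O)Nc3ccc(Cl)cc3Cl)n2CCCO)c2ccccc2c1=O` reaches only a limit, > 30000 nM.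

Of the two numbers shown, compound 1 has the higher one; the nearest is compound 2, and the step of a 3.3-fold lower number from compound 1 to compound 2 (0.52 log units; beyond the scatter) lies beyond the scatter. Compound 4 `CN(C)CCCn1nc(Cc2nnc(SCC(=O)Nc3ccc(Cl)cc3Cl)n2C)c2ccccc2c1=O` differs from compound 1 by 2-(dimethylamino)ethyl in place of hydrogen on a saturated chain carbon bound to an aromatic nitrogen. For the measured compounds named here, two measured steps touch the same kind of place: the step of a 3.3-fold lower number from compound 1 to compound 2 (0.52 log units; beyond the scatter) and the step of an at least 1.4-fold higher number from compound 1 to compound 3 (0.15 log units; that floor lies within the scatter), the latter ending at a limit (the limit of > 30000 nM in this assay, at which 1 of the 3 values shown sits). Between them, the step of an at least 4.6-fold higher number from compound 2 to compound 3 (0.67 log units; beyond the scatter) shows that lengthening the chain can move the number either way. The expected step is therefore only small, a 1.4-fold lower number from compound 1 to compound 4 (0.15 log units; within the scatter), and compound 4 is estimated at 15000 nM, within 4000 nM to 45000 nM.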

Compound 4, half-maximal inhibitory concentration: 16700 nM
Compound 4: the middle estimate sits 1.1-fold (0.05 log units) below what was measured; the measured number falls inside the stated range.
By their numbers in this assay, from the lowest: compound 2; then compounds 4 and 1 (each within the scatter of the next). At a limit, above all of these: compound 3.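

The step of a 1.3-fold lower number from compound 1 to compound 4 (0.10 log units; within the scatter) shows that in this assay a chain ending in a dimethylamino group can replace hydrogen at this place with no change that stands out from the scatter. Unlike the earlier chains ending in formyl or hydroxyl, this one carries a nitrogen, and compound 4 still gives a measurable number. Compound 3 alone stands at a limit, which is not a number: the limit of > 30000 nM in this assay, at which 1 of the 4 values shown sits.

On these data alone, whether a carboxylic acid or a primary amine at the end of this chain, or a longer chain, would move the number beyond the scatter stays open.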